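Bromo to chloro: a small halogen swap on a hydrazone series

This account rests on a few compounds, and the source may have more. Where it says the series, first, only, none or still open, it means among the compounds named here.

Two compounds share a core and differ at one aromatic position. Compound 1 `C(=N/Nc1nc(-c2ccccc2)cs1)\c1ccc(N2CCCC2)cc1` gives 25600 nM in an assay on isolated protein for inhibition of Amine oxidase [flavin-containing] A (Homo sapiens), read by fluorescence and Amplex Red, with a stated time of 30 min; on this read-out lower numbers stand for stronger inhibition and higher numbers for weaker inhibition. Compound 2 `Brc1ccc(-c2csc(N/N=C/c3ccc(N4CCCC4)cc3)n2)cc1` gives 61300 nM in this assay. For the measured compounds named here, the only measured step, bromo in place of hydrogen on an aromatic carbon, runs a 2.4-fold higher number from compound 1 to compound 2 (0.38 log units; beyond the scatter), so compound 2 holds the higher of the two numbers. Compound 3 `Clc1ccc(-c2csc(N/N=C/c3ccc(N4CCCC4)cc3)n2)cc1` makes a further change: chloro in place of bromo on an aromatic carbon. Going by the values given here, no measured step replaces one halogen with another, so the bromo-for-hydrogen step offers only indirect guidance; it suggests that a substituent at this position moves the number modestly, and a swap between two halogens is expected to move it less. Compound 3 is therefore expected to give about 50000 nM in this assay, within a range of 20000 nM to 125000 nM. The expected step is a 1.2-fold lower number from compound 2 to compound 3 (0.09 log units; within the scatter), not beyond the scatter.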

Compound 3, half-maximal inhibitory concentration: 45200 nM
Estimate against measurement, compound 3: 1.1-fold (0.04 log units) above, within the range that was stated.
By their numbers in this assay, from the lowest: compounds 1, 3 and 2 (each within the scatter of the next, the first and the last beyond it).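

In this assay, the halogen swap gives a 1.4-fold lower number from compound 2 to compound 3 (0.13 log units; within the scatter), so on this ring, para to a large group, chloro and bromo cannot be told apart. Chloro in place of hydrogen gives a 1.8-fold higher number from compound 1 to compound 3 (0.25 log units; within the scatter), while bromo in place of hydrogen gave a 2.4-fold higher number from compound 1 to compound 2 (0.38 log units; beyond the scatter); compound 3 therefore lies within the scatter of both other compounds, and only the bromo step is clearly measurable. Nothing available explains these numbers.

The compounds shown carry only hydrogen, chloro or bromo at this position, so it remains open whether fluoro, an amine, a carboxylic acid or a longer chain would shift the number further in either direction. From the compounds shown here alone, it is also open whether a halogen would behave the same way elsewhere on this ring.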